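Swapping Two Methyls for Two Ethyls on the Amine

The source may report more compounds than this note shows. Statements on the series, on what has been measured and on what is new or still open speak of the compounds shown alone.

Of the compounds shown here, three sharing one core have been tested in an assay on isolated protein for antagonist activity at advanced glycosylation end product-specific receptor (Homo sapiens), read by ELISA, with a stated time of 60 min, tested at 10 uM; on this read-out lower numbers stand for less inhibition and higher numbers for more inhibition at the one concentration tested (going by the name of the read-out). Compound 2 `CCCCc1sc(-c2ccc(OCCCN(C)C)cc2)nc1-c1ccc(Oc2ccc(Cl)cc2)cc1` gives 46.2% in this assay. Its closest neighbour is compound 1 `CCCCc1sc(C(=O)Nc2ccc(OCCCN(CC)CC)cc2)nc1-c1ccc(Oc2ccc(Cl)cc2)cc1`, which gives 48.1%, a number within the usual scatter of compound 2. Compound 3 `CCCCc1sc(-c2ccc(Oc3ccc(Cl)cc3)cc2)nc1-c1ccc(OCc2ccccc2)cc1` gives 2.4%, a number well beyond the scatter below compound 2.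

Compound 4 `CCCCc1sc(-c2ccc(OCCCN(CC)CC)cc2)nc1-c1ccc(Oc2ccc(Cl)cc2)cc1` has not been measured. It differs from compound 2 in one place: diethylamino in place of dimethylamino on a saturated chain carbon, three bonds along the chain from an oxygen on an aromatic ring. Compound 1 already carries a diethylamino group on the same kind of chain and gives 48.1%, so no step beyond the scatter is expected here, in either direction. Compound 4 is therefore estimated to give 48% in this assay, in the range 36% to 60%, an expected step of a number 1.8 percentage points higher from compound 2 to compound 4 (within the scatter).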

Compound 4, a percentage reported as inhibition, at one concentration (the size of the read-out at that concentration, not a potency): 58.9%
Compound 4: middle estimate off by 10.9 percentage points, on the low side; measured number inside the range.
By their numbers in this assay, from the lowest: compound 3; then compounds 2 and 1 (each within the scatter of the next); then compound 4.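

Placing diethylamino in place of dimethylamino gives a number 12.7 percentage points higher from compound 2 to compound 4 (beyond the scatter) in this assay, and this is the first comparison in which only the amine changes. At this position, then, the groups on the amine nitrogen affect the read-out, and the two ethyls go with more inhibition at the one concentration tested. No measurement shown gives a reason for this step.

Still open, on these data alone, is whether dipropylamino or a ring amine such as piperidine would continue this rise or reverse it. A longer or shorter chain carrying diethylamino also remains untested among these compounds.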